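A few compounds are considered here, and "the series" means these few. Any claim that something is new, unique, unknown or untested is made for them only; others in the source may bear on it.

Measured in a functional assay on SK-OV-3 cells (Homo sapiens) for inhibition, read by MTT assay; a lower number here means a stronger inhibitor, a higher number a weaker inhibitor:
- compound 1 `COc1ccc(/C=C2\c3cc(OC)c(OC)c(OC)c3CC[C@@H]2O)cc1F`: 1 nM
- compound 2 `COc1ccc(/C=C2\c3cc(OC)c(OC)c(OC)c3CC[C@@H]2O)cc1C(N)=O`: 1440 nM

Compound 1 holds the lower of these two numbers, so it is the stronger inhibitor. Compound 3 `COc1ccc(/C=C2\c3cc(OC)c(OC)c(OC)c3CC[C@H]2O)cc1F` has not been measured, and its change from compound 1 is this: the two compounds have the same atoms and bonds and differ only in configuration as drawn: 1 of 2 stereo elements differ; a stereocentre at a saturated ring carbon is drawn S in compound 1 and R in compound 3. Among the measured compounds shown here, the only measured step, a 1400-fold higher number from compound 1 to compound 2 (3.16 log units; beyond the scatter), swaps a group at a different place, so it shows that one change can matter greatly but says nothing direct about a stereocentre. With compound 1 at 1 nM, at the low end, a rise in this assay seems likelier than a fall. The expected change is a 20-fold higher number from compound 1 to compound 3 (1.30 log units; beyond the scatter). Compound 3 is estimated at 20 nM, with an expected range of 1 nM to 400 nM.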

Compound 3, half-maximal inhibitory concentration: 720 nM
Beside the measured number, compound 3's estimate is 36-fold (1.56 log units) below it, and the stated range ends below it.
By their numbers in this assay, from the lowest: compound 1; then compounds 3 and 2 (each within the scatter of the next).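

In this assay, the stereocentre at the saturated ring carbon proves decisive on its own: a 720-fold higher number from compound 1 to compound 3 (2.86 log units; beyond the scatter). No atom or bond changes, so this large step shows that the spatial arrangement at this position matters, which the swap of fluoro for carbamoyl at another place could not show. The step can be assigned to this stereocentre alone because of one plain fact: the fact that compounds 1 and 3 differ only in the configuration as drawn.

On these data alone, the effect of changing the other stereo element remains open. So does whether an amine or a chloro group in place of the fluoro would keep the low number of compound 1.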